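Adding a Methoxycarbonyl Group: What Lipophilicity to Expect

The compounds below may be only part of what the source reports. "The series", "measured", "known", "first", "only" and "open" are said of these compounds alone.

Of the compounds shown here, three have been measured in a physicochemical assay for lipophilicity, read by HPLC, measured as octanol-water partition, at pH 11; a higher number here means a more lipophilic compound, a lower number a more polar compound. Compound 1 `Cn1c(NC(=O)c2cccnc2)cc2ccccc21` gives -0.1 in this assay. Compound 2 `c1cc2ccc(CN3CCCCC3)ccc-2c1` reaches only the limit of the method in this assay, > 5.5, so for it no number is known. Compound 3 `CN(C)C(=O)c1cn(C)c2ccccc12` gives 1.3 in this assay, the higher of the two numbers that have been read; compound 1 lies well below it, a gap beyond the usual scatter of repeated measurements.

Compound 4 `COC(=O)c1ccc2c(C(=O)N(C)C)cn(C)c2c1` has not yet been measured in this assay. It differs from compound 3 in one place, (methoxycarbonyl in place of hydrogen on an aromatic carbon). The group that enters carries no charge and adds one carbonyl with an attached methoxy group on the aromatic carbon described above. Among the measured compounds shown here, none of the measured pairs share exactly this change, so no measured step can be pointed to as a guide, and nothing among the three measured compounds tells how this particular group shifts the reading.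

Taking compound 3 as the starting point, the step from adding the methoxycarbonyl group is expected to be small, a number 0.10 log units higher from compound 3 to compound 4 (within the scatter), a change no larger than the scatter of the method in either direction. For compound 4 a value of 1.4 is estimated, between 0.9 and 1.9.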

Compound 4, distribution coefficient: 1.9
For compound 4 the middle estimate is 0.50 log units below the measured one; the measured number falls inside the stated range.
By their numbers in this assay, from the lowest: compound 1; then compound 3; then compound 4. At a limit, above all of these: compound 2.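

In this assay, placing methoxycarbonyl in place of hydrogen on an aromatic carbon, meta to a fused ring and para to a fused ring, gives a number 0.60 log units higher from compound 3 to compound 4 (beyond the scatter). Among the compounds shown here, the other measured compounds offered no pair differing in one place, so this is the only measured step here, and it shows that on this core, at this position, the group that enters raises the reading by more than repeat measurements alone would account for. Nothing measured here gives a cause for the step.

As far as these compounds go, whether an amine, a carboxylic acid or an ester with a longer chain on the same aromatic carbon would move the reading in the same direction stays open, as does whether methoxycarbonyl would give a similar step on another carbon of the six-membered ring. A single pair also cannot tell whether this step would carry over to a different core, so for now it describes only the change from hydrogen to methoxycarbonyl on this one.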